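Swapping hydrogen for chloro on a uracil-like lead

The source may report more compounds than this note shows. Statements on the series, on what has been measured and on what is new or still open speak of the compounds shown alone.

Compound 1 `O=C1O/C(=C\Cn2cc(I)c(=O)[nH]c2=O)C(OCc2ccccc2)=C1OCc1ccccc1` gives 3900 nM
Compound 2 `O=C1O/C(=C\Cn2ccc(=O)[nH]c2=O)C(OCc2ccccc2)=C1OCc1ccccc1` gives 4800 nM

Among the measured compounds shown here, in a functional assay on MOLT-4 cells (Homo sapiens) for inhibition (a lower number here means a stronger inhibitor, a higher number a weaker inhibitor), compound 2 gives 4800 nM and sits within the scatter of compound 1, the only other compound measured so far. Compound 3 `O=C1O/C(=C\Cn2cc(Cl)c(=O)[nH]c2=O)C(OCc2ccccc2)=C1OCc1ccccc1` differs from compound 2 in one place (chloro in place of hydrogen on an aromatic carbon), with chloro in place of hydrogen on an aromatic carbon. For the measured compounds named here, one measured step bears on this change, a swap between hydrogen and iodo: a 1.2-fold higher number from compound 1 to compound 2 (0.09 log units; within the scatter) and it lies within the scatter. Going by the values given here, no chloro compound has been measured yet, so this single step is the only guide. No shift beyond the scatter, in either direction, is therefore expected in this assay for this change. The estimated step is a 1.1-fold lower number from compound 2 to compound 3 (0.05 log units; within the scatter) and it stays within the scatter. Compound 3 is expected near 4300 nM with an estimated range from 2200 nM to 8000 nM in repeat measurements.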

Compound 3, half-maximal inhibitory concentration: 6100 nM
Compound 3: middle estimate off by 1.4-fold (0.15 log units), on the low side, and the stated range covers the measured number.
By their numbers in this assay, from the lowest: compounds 1, 2 and 3 (each within the scatter of the next).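

In this assay, placing chloro on this aromatic carbon gives a 1.3-fold higher number from compound 2 to compound 3 (0.10 log units; within the scatter), and exchanging iodo for chloro at the same carbon gives a 1.6-fold higher number from compound 1 to compound 3 (0.19 log units; within the scatter). With hydrogen, chloro and iodo now all compared at this one place, every step stays within the scatter, so this assay does not separate these groups here. Nothing measured alongside these numbers offers an explanation for this flat result.

As far as these compounds go, whether a different kind of group on this carbon, such as an amine, a carboxylic acid or a longer chain, would move the number beyond the scatter remains open. Also open, from the compounds shown here alone, is whether hydrogen, chloro and iodo would stay this close if the rest of the shared core were changed.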